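The compounds below may be only part of what the source reports. "The series", "measured", "known", "first", "only" and "open" are said of these compounds alone.

Measured so far in a functional assay on CCRF-CEM cells (Homo sapiens) for antiproliferative activity, with a stated time of 72 h; on this read-out lower numbers stand for stronger inhibition and higher numbers for weaker inhibition:
- Compound 1 `OC[C@H]1O[C@@H](n2cnc3c(NCc4ccc(F)cc4)ncnc32)[C@H](O)[C@@H]1O`: 1250 nM
- Compound 2 `OC[C@H]1O[C@@H](n2cnc3c(NCc4ccc(Br)cc4)ncnc32)[C@H](O)[C@@H]1O`: 20600 nM
- Compound 3 `COc1ccccc1CNc1ncnc2c1ncn2[C@@H]1O[C@H](CO)[C@@H](O)[C@H]1O`: 3200 nM

Compound 3 has the second highest of the three numbers. The steps that place it are a 2.6-fold higher number from compound 1 to compound 3 (0.41 log units; beyond the scatter) and a 6.4-fold lower number from compound 2 to compound 3 (0.81 log units; beyond the scatter), both modest.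

The compound still to be measured is compound 4 `OC[C@H]1O[C@@H](n2cnc3c(NCc4ccc(Cl)c(Cl)c4)ncnc32)[C@H](O)[C@@H]1O`. The change is 3,4-dichlorophenyl in place of 2-methoxyphenyl on a saturated chain carbon bound to a nitrogen on an aromatic ring, which puts 3,4-dichlorophenyl in place of 2-methoxyphenyl on a saturated chain carbon bound to a nitrogen on an aromatic ring.

The closest evidence is the large halogen exchange, a 16-fold higher number from compound 1 to compound 2 (1.22 log units; beyond the scatter). It shows that halogen identity alone can shift the number strongly in this series. Going by the values given here, no measured compound carries a chloro group, so the step to compound 4 is an extrapolation, and the halogenated compounds lie on both sides of compound 3. The expectation leans towards compound 2 at 20600 nM rather than compound 1, but only weakly.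

A modest step towards a higher number is therefore expected in this assay, estimated as a 2.2-fold higher number from compound 3 to compound 4 (0.34 log units; beyond the scatter).

For compound 4 the estimated value is 7000 nM, with an expected range of 1800 nM to 27000 nM.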

Compound 4, half-maximal inhibitory concentration: 3800 nM
Compound 4: middle estimate off by 1.8-fold (0.27 log units), on the high side, within the range that was stated.
By their numbers in this assay, from the lowest: compound 1; then compounds 3 and 4 (each within the scatter of the next); then compound 2.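

Replacing 2-methoxyphenyl with 3,4-dichlorophenyl on the saturated chain carbon bound to a nitrogen on an aromatic ring gives no readable change in this assay, with a 1.2-fold higher number from compound 3 to compound 4 (0.07 log units; within the scatter), so at this position a group with one hydrogen-bond acceptor and a group with none are not separated in this pair. Halogen on the phenyl ring does not by itself set the level, since a 5.4-fold lower number from compound 2 to compound 4 (0.73 log units; beyond the scatter) and a 3.0-fold higher number from compound 1 to compound 4 (0.48 log units; beyond the scatter) place the three halogen-bearing compounds apart beyond the scatter, with compound 1 lowest of all four compounds and compound 3, which carries no halogen, level with compound 4. Nothing available bears on the origin of these differences.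

Still open, from the compounds shown here alone, is whether a single chloro group on the phenyl ring gives a number like that of the 3,4-dichlorophenyl group or one closer to the fluoro or bromo compounds, which would show whether the second chlorine matters at all. Also open, going by these compounds, is how the series responds at this place to a saturated ring such as cyclohexyl, to a phenyl ring bearing an amine or a carboxylic acid, or to a longer chain in place of the benzyl link.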